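The source may hold more compounds than are shown below. What is called first, only, known or untested is meant among the compounds shown, and "the series" means these compounds.

Measured compounds:
- Compound 1 `Oc1cccc(-c2cc(-c3ccc(F)cc3)cc(-c3ccccc3O)n2)c1` in a functional assay on HeLa cells (Homo sapiens) for inhibition (a higher number here means a weaker inhibitor, a lower number a stronger inhibitor), gives > 50000 nM, which is a limit of the assay and not a number.
- Compound 2 `Oc1cccc(-c2cc(-c3ccc(C(F)(F)F)cc3)cc(-c3ccccc3O)n2)c1` gives > 50000 nM, again only a limit.
- Compound 3 `Oc1ccccc1-c1cc(-c2ccc(OC(F)(F)F)cc2)cc(-c2ccccc2O)n1` gives > 50000 nM, also a limit.

Compound 3 thus stands at the limit, alongside the other two values shown, as the limit of > 50000 nM in this assay, at which 3 of the 3 values shown sit, states. For the measured compounds named here, the one comparable step, a step that the two limits leave unreadable from compound 1 to compound 2, cannot be read in size, since both of its values are limits.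

Compound 4 `Oc1cccc(-c2cc(-c3ccc(OC(F)(F)F)cc3)cc(-c3ccccc3O)n2)c1` differs from compound 3 by 3-hydroxyphenyl in place of 2-hydroxyphenyl on an aromatic carbon. Going by the values given here, no measured step speaks to this change, and every value shown sits at the limit. For compound 4 the expected step is a step that the limit leaves unreadable from compound 3 to compound 4, which is to say none that can be read. Compound 4 is therefore estimated at 100000 nM, with a range from 30000 nM to 500000 nM, most likely reported again as a limit.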

Compound 4, half-maximal inhibitory concentration: 20600 nM
Compound 4: middle estimate off by 4.9-fold (0.69 log units), on the high side; the measured number lies below the stated range.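

In this assay, for the compounds shown here, 3-hydroxyphenyl in place of 2-hydroxyphenyl next to the ring nitrogen gives the first measurable number in this set, an at least 2.4-fold lower number from compound 3 to compound 4 (0.38 log units; beyond the scatter). With 3-hydroxyphenyl in that place, the other substituent also counts: trifluoromethoxy in place of trifluoromethyl gives an at least 2.4-fold lower number from compound 2 to compound 4 (0.38 log units; beyond the scatter), and trifluoromethoxy in place of fluoro gives an at least 2.4-fold lower number from compound 1 to compound 4 (0.38 log units; beyond the scatter). Each size is only a minimum, because one end of every step is a limit: the limit of > 50000 nM in this assay, at which 3 of the 4 values shown sit.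

The compounds shown leave open whether 4-hydroxyphenyl in that place, or an amine or a carboxylic acid in place of trifluoromethoxy, would lower the number further.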